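Biaryl replacement of the dimethylcarbamoyl ethenyl arm

The source may hold more compounds than are shown below. What is called first, only, known or untested is meant among the compounds shown, and "the series" means these compounds.

Of the compounds shown here, three of the shared core have been measured in an assay on isolated protein with Bile acid receptor (Homo sapiens) as the target; on this read-out lower numbers stand for an effect already at smaller amounts and higher numbers for an effect only at larger amounts of compound. Compound 1 `COC(=O)/C=C/c1cccc(N(Cc2ccc(/C=C/c3ccccc3F)cc2)C(=O)C2CCCCC2)c1` gives 64 nM, and compound 2 `COC(=O)/C=C/c1cccc(N(Cc2ccc(/C=C/c3scnc3C)cc2)C(=O)C2CCCCC2)c1` gives 227 nM. For compound 3 `COC(=O)/C=C/c1cccc(N(Cc2ccc(/C=C/C(=O)N(C)C)cc2)C(=O)C2CCCCC2)c1` the readout is only a limit, > 1000 nM, as recorded for (the limit of > 1000 nM in this assay, at which 1 of the 3 values shown sits). Compound 3 therefore stands at the weak end of the series: the change an at least 15-fold higher number from compound 1 to compound 3 (1.19 log units; beyond the scatter) and the change an at least 4.4-fold higher number from compound 2 to compound 3 (0.64 log units; beyond the scatter) both show that swapping an aromatic ring on the double-bonded chain carbon for dimethylcarbamoyl raises the number well beyond the scatter, while a 3.5-fold higher number from compound 1 to compound 2 (0.55 log units; beyond the scatter) shows that the two aromatic rings differ between themselves by a smaller amount.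

Compound 4 `COC(=O)/C=C/c1cccc(N(Cc2ccc(-c3ccc(OC(F)(F)F)cc3)cc2)C(=O)C2CCCCC2)c1` is not yet measured. It differs from compound 3 by 4-(trifluoromethoxy)phenyl in place of 2-(dimethylcarbamoyl)ethenyl on an aromatic carbon. Among the measured compounds shown here, the two steps that bear on it, the one from compound 1 and the one from compound 2 to compound 3, were large and modest and both point the same way: an aromatic group in this arm gives a lower number than the dimethylcarbamoyl chain. For the measured compounds named here, no measured pair reproduces the loss of the two double bonds outside aromatic rings, so the size is uncertain. Compound 4 is expected to fall by an at least 6.6-fold lower number from compound 3 to compound 4 (0.82 log units; beyond the scatter) in this assay. The estimate for compound 4 is 150 nM, within the range 40 nM to 600 nM.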

Compound 4, half-maximal effective concentration: 264 nM
For compound 4 the middle estimate is 1.8-fold (0.25 log units) below the measured one; the measured number falls inside the stated range.
By their numbers in this assay, from the lowest: compound 1; then compounds 2 and 4 (each within the scatter of the next). At a limit, above all of these: compound 3.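

In this assay the arm does not need an ethenyl link to stay clear of the dimethylcarbamoyl chain: 4-(trifluoromethoxy)phenyl directly on the aromatic carbon gives an at least 3.7-fold lower number from compound 3 to compound 4 (0.57 log units; beyond the scatter) as a bound only, and compound 3 is read only at a limit: the limit of > 1000 nM in this assay, at which 1 of the 4 values shown sits.

Set against the 2-(4-methyl-1,3-thiazol-5-yl)ethenyl arm, the directly attached ring gives a 1.2-fold higher number from compound 2 to compound 4 (0.07 log units; within the scatter) and no order can be drawn between the two. Set against the 2-(2-fluorophenyl)ethenyl arm, it gives a 4.1-fold higher number from compound 1 to compound 4 (0.62 log units; beyond the scatter) and leaves compound 1 with the lowest number of the four, so an aromatic ring in this arm does not alone settle the read-out.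

Compound 4 differs from compound 1 both in the missing ethenyl link and in the ring substituent, and the share of each in that step cannot be separated. Going by these compounds, a 2-fluorophenyl group directly on the aromatic carbon, or a 4-(trifluoromethoxy)phenyl group on the ethenyl link, would separate the two, and the effect of a carboxylic acid in place of the methyl ester remains open.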